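Working notes: cytotoxicity limits across three analogues

A few compounds are considered here, and "the series" means these few. Any claim that something is new, unique, unknown or untested is made for them only; others in the source may bear on it.

Measured so far:
compound 1, `CCOC(=O)c1c(-c2cccc(OC)c2)[nH]c2cc(C(F)(F)F)ccc2c1=O` — > 21500 nM
compound 2, `CCOC(=O)c1c(-c2cccc(Cl)c2)[nH]c2cc(C(F)(F)F)ccc2c1=O` — > 21500 nM
compound 3, `CCOC(=O)c1c(-c2cccc(-c3ccccc3)c2)[nH]c2cc(OC)c(OC)cc2c1=O` — > 21500 nM

In an ADME assay on Raji cells (Homo sapiens) for cytotoxicity, read by luminescence, with a stated time of 72 h (a lower number here means that less compound is needed, a higher number that more compound is needed for the effect), compound 1 reaches only a limit, > 21500 nM. Compound 2 likewise gives only a limit in this assay, > 21500 nM. The change between them, (chloro in place of methoxy on an aromatic carbon), therefore yields a step that the two limits leave unreadable from compound 1 to compound 2; both values sit at the limit of > 21500 nM in this assay, at which 3 of the 3 values shown sit. Compound 3 also stops at a limit in this assay, > 21500 nM. How the core of compound 3 differs from the core of compound 1 is not broken down here.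

Compound 4, `CCOC(=O)c1c(-c2cccc(-c3ccccc3)c2)[nH]c2cc(Cl)c(OC)cc2c1=O`, has not yet been measured in this assay. It differs from compound 3 by chloro in place of methoxy on an aromatic carbon. This is the same kind of change as from compound 1 to compound 2, but the surroundings differ: in compound 2 the chloro stands on a six-membered aromatic ring of carbon only, meta to a large group, whereas in compound 4 it sits on a ring that is part of a fused or bridged system of two rings, ortho to a methoxy group, meta to a fused ring and para to a fused ring.

The expectation rests on compound 3 giving only a limit, > 21500 nM. It also rests on the earlier step being a step that the two limits leave unreadable from compound 1 to compound 2. The step is expected to come out as a step that the limit leaves unreadable from compound 3 to compound 4. Compound 4 is estimated at 25000 nM, within a range from 10000 nM to 60000 nM, most likely again reported only as a limit.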

Compound 4, half-maximal effective concentration: > 21500 nM
Compound 4 ended at the assay's limit; the forecaster's own chance of this, stated with the estimate: 85%; the middle value is on the limit's open side.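

In this assay compound 4 gives > 21500 nM, which is a limit and not a number, so no new step can be read from compound 3 to compound 4. Compounds 1 to 4 all stop at the same limit: the limit of > 21500 nM in this assay, at which 4 of the 4 values shown sit.

The compounds shown leave open whether chloro in place of methoxy on an aromatic carbon changes the concentration needed for the effect at all.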